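A larger ring on the weaker stereoisomer

The source may report more compounds than this note shows. Statements on the series, on what has been measured and on what is new or still open speak of the compounds shown alone.

Measured so far in a functional assay (trachea) for inhibition, with Cavia porcellus as the target; a lower number here means a stronger inhibitor, a higher number a weaker inhibitor:
Compound 1 `CC1(C)c2ccc([N+](=O)[O-])cc2[C@@H](N2CCCC2=O)[C@@H]1O`: 2800 nM
Compound 2 `CC1(C)c2ccc([N+](=O)[O-])cc2[C@@H](N2CCCC2=O)[C@H]1O`: > 20000 nM

Going by these compounds, the entry for compound 2, > 20000 nM, is a limit of the assay and not a number, so its true position is unknown. Going by the values given here, the only measured step, an at least 7.1-fold higher number from compound 1 to compound 2 (0.85 log units; beyond the scatter), goes with the fact that compounds 1 and 2 differ only in the configuration as drawn. It concerns configuration alone and gives no direct measure for a change of substituent.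

Compound 3 `CC1(C)c2ccc([N+](=O)[O-])cc2[C@@H](N2CCCCC2=O)[C@H]1O` has the same configuration as drawn as compound 2. It carries 2-oxopiperidin-1-yl in place of 2-oxopyrrolidin-1-yl on a saturated ring carbon. Among the compounds with values here, no measured pair in this small set tests that exchange, so the expectation in this assay is for no step beyond the scatter, and another limit is the likeliest report. The expected step is a number no higher from compound 2 to compound 3 (the limit leaves the size open), a figure that can only be approximate given the limit it starts from. For compound 3 the estimated value is 20000 nM, with an expected range of 7000 nM to 50000 nM.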

Compound 3, half-maximal inhibitory concentration: 350 nM
For compound 3 the middle estimate is 57-fold (1.76 log units) above the measured one, and the stated range ends above it.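

Going by these compounds alone, until this result, the only step seen in this assay concerned configuration, whereas the exchange of 2-oxopyrrolidin-1-yl for 2-oxopiperidin-1-yl on a saturated ring carbon, with the configuration as drawn held fixed, gives an at least 57-fold lower number from compound 2 to compound 3 (1.75 log units; beyond the scatter), which shows that the substituent at this position matters in its own right and not only its orientation. The entry for compound 2, > 20000 nM, is a limit of the assay and not a number. The size of the step is therefore only a minimum, and the earlier step could say nothing about this exchange for a plain reason: the fact that compounds 1 and 2 differ only in the configuration as drawn

The compounds shown leave open whether the same exchange would carry over to the configuration of compound 1, since only the configuration of compound 2 has a pair for it, and compound 3 differs from compound 1 in two places, so the two are not compared here. They also leave open how far the trend in ring size extends, for example to a seven-membered ring such as 2-oxoazepan-1-yl, and whether the carbonyl is needed, as a piperidin-1-yl group on the same saturated ring carbon would test.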